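A few compounds are considered here, and "the series" means these few. Any claim that something is new, unique, unknown or untested is made for them only; others in the source may bear on it.

Measured so far:
compound 1, `CC[C@H](C)[C@H](NC(=O)CN(c1nc(Cl)nc2[nH]cnc12)C1CC1)C(=O)O`, gives 21.4%
compound 2, `O=C(CN(c1nc(Cl)nc2[nH]cnc12)C1CC1)N[C@@H](CO)C(=O)O`, gives 39%

In a functional assay on the whole organism (Tail, strain ICR) with Mus musculus as the target, in the tail flick test, with a stated time of 120 min, at a dose of 25 umol/kg by the oral route (a higher number here means a stronger effect of the compound at the dose given, a lower number a weaker effect), compound 2 stands highest of the two numbers. Within the data shown here, the single measured step, a number 17.6 percentage points higher from compound 1 to compound 2 (beyond the scatter), lies beyond the scatter and was a change at the very place now in question. Compound 3, `O=C(O)CNC(=O)CN(c1nc(Cl)nc2[nH]cnc12)C1CC1`, differs from compound 2 by hydrogen in place of hydroxymethyl on a saturated chain carbon bound to an amide-type nitrogen and a carbonyl carbon. Among the measured compounds shown here, no measured step exchanges hydroxymethyl for hydrogen, so the earlier step only shows that changes at this place can shift the number modestly. Compound 3 is therefore expected to give about 30%, between 10% and 52%. The expected step is a number 9 percentage points lower from compound 2 to compound 3 (within the scatter), a modest drop, though none beyond the scatter would not surprise.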

Compound 3, a percentage reported as activity, at one dose (the size of the read-out at that dose, not a potency): 19.8%
Estimate against measurement, compound 3: 10.2 percentage points above; low and high end bracket the measured number.
By their numbers in this assay, from the lowest: compounds 3 and 1 (each within the scatter of the next); then compound 2.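

In this assay, the loss of hydroxymethyl is now measured directly: hydrogen in its place gives a number 19.2 percentage points lower from compound 2 to compound 3 (beyond the scatter). Hydrogen in place of sec-butyl gives a number 1.6 percentage points lower from compound 1 to compound 3 (within the scatter), so among these three side groups only hydroxymethyl stands apart, while a bare hydrogen and sec-butyl cannot be told apart. No supporting measurement explains why hydroxymethyl differs. Still open, on these data alone, is whether a methyl group, or a longer chain ending in an amine, at this place would match compound 2 or fall with compound 1 and compound 3.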